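The compounds below may be only part of what the source reports. "The series", "measured", "known", "first", "only" and "open" are said of these compounds alone.

Compound 1, `N#Cc1ccc(C(c2ccc(C#N)cc2)n2cc(COc3ccccc3)nn2)cc1`, and compound 2, `N#Cc1ccc(C(c2ccc(C#N)cc2)n2cc(COc3ccc(Cl)cc3)nn2)cc1`, share a core and differ in one place, described as chloro in place of hydrogen on an aromatic carbon. In an assay on isolated protein for inhibition of Aromatase (Homo sapiens), read by fluorescence and colorimetric assay, with a stated time of 30 min (on this read-out higher numbers stand for weaker inhibition and lower numbers for stronger inhibition), compound 1 gives 11000 nM, and compound 2 gives 16100 nM. The step between them, a 1.5-fold higher number from compound 1 to compound 2 (0.17 log units; within the scatter), is of a size that ordinary repetition of the measurement could produce, so the two numbers cannot be told apart with confidence.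

Compound 3, `c1ccc(Cn2cc(COc3ccccc3)nn2)cc1`, rests on a different core; how its core differs from that of compound 1 is not broken down here. In this assay compound 3 gives 10600 nM, a number that lies within the scatter of the values of compound 1 and compound 2 alike.

Compound 4, `Clc1ccc(OCc2cn(Cc3ccccc3)nn2)cc1`, is not yet measured. It stands to compound 3 as compound 2 stands to compound 1: the difference is chloro in place of hydrogen on an aromatic carbon, at a place described in the same words as before, so this is the same change carried onto the second core. Among the compounds with values here, the only guide to what the change does is the step from compound 1 to compound 2, which was within the scatter, and the expectation is that the step from compound 3 to compound 4 will be similar, a 1.4-fold higher number from compound 3 to compound 4 (0.14 log units; within the scatter), because the value of compound 3, 10600 nM, is so close to that of compound 1. Accordingly compound 4 is estimated to give 14500 nM in this assay, with a likely range from 7000 nM to 30000 nM.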

Compound 4, half-maximal inhibitory concentration: 5040 nM
For compound 4 the middle estimate is 2.9-fold (0.46 log units) above the measured one; the whole stated range lies above it.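

The same change on the second core gives a 2.1-fold lower number from compound 3 to compound 4 (0.32 log units; beyond the scatter) in this assay, a modest strengthening of inhibition that lies beyond the scatter. Chloro in place of hydrogen on an aromatic carbon therefore does not carry over unchanged from one core to the other in this assay: the same change on two cores in this assay, a 1.5-fold higher number (0.17 log units; within the scatter) from compound 1 to compound 2 and a 2.1-fold lower number (0.32 log units; beyond the scatter) from compound 3 to compound 4, 3.1-fold (0.49 log units) apart, beyond the scatter of two such steps. This rests on a single pair on each core, with one group at one place, and it does not show why the two cores part ways, nor how the change would behave on any further core in the series.

The compounds shown carry only hydrogen or chloro at this place, para to a large group, so it remains open whether a bromo, a methoxy or an amine there would follow the pattern of the first core, that of the second, or neither. Also open, on these data alone, is which part of the difference between the core of compound 1 and the core of compound 3 goes with the difference between the two steps, as the two cores are not joined here by any intermediate compound.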